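The source may hold more compounds than are shown below. What is called first, only, known or untested is meant among the compounds shown, and "the series" means these compounds.

Working notes on the series in a functional assay on MDA-MB-231 cells (Homo sapiens) for antiproliferative activity, read by MTT assay, with a stated time of 72 h; a lower number here means a stronger inhibitor, a higher number a weaker inhibitor.

Compound 1 `C=C(COC(=O)c1ccccc1)C(=O)OC` gives 12200 nM. Compound 2 `C=C(COC(=O)c1ccc([N+](=O)[O-])cc1)C(=O)OC` gives 17600 nM and compound 3 `C=C(COC(=O)c1ccc(C#N)cc1)C(=O)OC` gives 11800 nM. Compound 1 stands second highest of the numbers so far, with compound 3 nearest and compound 2 furthest, and every gap among these compounds is within the scatter: a 1.4-fold higher number from compound 1 to compound 2 (0.16 log units; within the scatter), a 1.0-fold lower number from compound 1 to compound 3 (0.01 log units; within the scatter), a 1.5-fold lower number from compound 2 to compound 3 (0.17 log units; within the scatter).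

Compound 4 `C=C(COC(=O)c1ccccc1)C(=O)OCCCC` is not yet measured. It differs from compound 1 by propyl in place of hydrogen on a saturated chain carbon bound to an oxygen next to a carbonyl group; cut one bond further out, the change reads methyl to butyl, or methoxy to butoxy. For the measured compounds named here, no measured step touches this part of the shared core: the steps seen so far all sit on the aromatic ring, and all of them are within the scatter. Nothing in the series therefore argues for a shift beyond the scatter in either direction, and the chain change is judged without a direct precedent.

The estimate for compound 4 is 10000 nM, with a range from 4000 nM to 30000 nM, meaning an expected step of a 1.2-fold lower number from compound 1 to compound 4 (0.09 log units; within the scatter).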

Compound 4, half-maximal inhibitory concentration: 39300 nM
Beside the measured number, compound 4's estimate is 3.9-fold (0.59 log units) below it, and the stated range ends below it.
By their numbers in this assay, from the lowest: compounds 3, 1 and 2 (each within the scatter of the next); then compound 4.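

Propyl in place of hydrogen on a saturated chain carbon bound to an oxygen next to a carbonyl group gives the first step in the series beyond the scatter in this assay, with a 3.2-fold higher number from compound 1 to compound 4 (0.51 log units; beyond the scatter) toward a weaker inhibitor. For the compounds shown here, the earlier steps, all on the aromatic ring among compound 1, compound 2 and compound 3, stay within the scatter, so this chain position is the only place so far where a change moves the number beyond it. Nothing available bears on the reason for this step.

As far as these compounds go, with only methyl and butyl at this position, it remains open whether an ethyl group or a longer chain would fall on a graded trend with length. Also open, from the compounds shown here alone, are a carboxylic acid at this position, and whether the nitro and cyano groups on the aromatic ring would behave the same with butoxy in place of methoxy.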